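The compounds below may be only part of what the source reports. "The series", "measured", "known", "first", "only" and "open" are said of these compounds alone.

Compound 1 `CC(=O)N1CCC(C(=O)N(CCCN2CCN(Cc3ccc(S(C)(=O)=O)cc3)CC2)c2ccc(C)c(Cl)c2)CC1` in an ADME assay (Homo sapiens) for cytotoxicity (on this read-out higher numbers stand for lower toxicity in this test and lower numbers for higher toxicity in this test), gives > 49200 nM, a limit of the assay.
Compound 2 `CC(=O)N1CCC(C(=O)N(CCCN2CCN(Cc3ccc(Cl)cc3)CC2)c2ccc(C)c(Cl)c2)CC1` in this assay gives 37600 nM.
Compound 3 `CC(=O)N1CCC(C(=O)N(CCCN2CCN(c3ccccn3)CC2)c2ccc(C)c(Cl)c2)CC1` in this assay gives > 58300 nM, again a limit rather than a number.

Compound 3 therefore stands only at a limit, and one of the other two values is a limit as well (the limit of > 58300 nM in this assay, at which 1 of the 3 values shown sits). The change to compound 4 `CC(=O)N1CCC(C(=O)N(CCCN2CCN(Cc3ccc(C(F)(F)F)cc3)CC2)c2ccc(C)c(Cl)c2)CC1` is 4-(trifluoromethyl)benzyl in place of pyridin-2-yl on an amine nitrogen in a ring. For the measured compounds named here, two measured steps touch compound 3: an at least 1.5-fold higher number from compound 2 to compound 3 (0.19 log units; that floor lies within the scatter), and a step that the two limits leave unreadable from compound 1 to compound 3. Going by the values given here, of the three compounds, compound 2 carries a 4-chlorobenzyl and compound 1 a 4-(methylsulfonyl)benzyl, both of the same kind as the 4-(trifluoromethyl)benzyl that enters in compound 4, and between those two an at least 1.3-fold lower number from compound 1 to compound 2 (0.11 log units; that floor lies within the scatter), with the one number sitting at a limit (the limit of > 49200 nM in this assay, at which 1 of the 3 values shown sits). None of these steps is readable as beyond the scatter. Compound 4 is thus expected to land close to the benzyl pair, giving an at least 1.4-fold lower number from compound 3 to compound 4 (0.16 log units; that floor lies within the scatter), a step that cannot be sized against a limit. The estimate for compound 4 in this assay is 40000 nM, expected to lie between 18000 nM and 90000 nM.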

Compound 4, half-maximal cytotoxic concentration: 30500 nM
Compound 4: middle estimate off by 1.3-fold (0.12 log units), on the high side, and the stated range covers the measured number.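

In this assay, compound 4 adds a second exact number to the benzyl series, so one step in this series can now be read without a limit at either end: a 1.2-fold lower number from compound 2 to compound 4 (0.09 log units; within the scatter), which means that chloro and trifluoromethyl on this aromatic carbon cannot be told apart in this test. The two steps that reach compound 4 from the limit values, an at least 1.9-fold lower number from compound 3 to compound 4 (0.28 log units; that floor lies within the scatter) and an at least 1.6-fold lower number from compound 1 to compound 4 (0.20 log units; that floor lies within the scatter), give only minimum sizes, and neither minimum shows a real difference, whether the group replaced is the pyridin-2-yl on the ring nitrogen or the methylsulfonyl on the aromatic carbon. The value of compound 3 remains a limit of the assay, so the true size of the change from pyridin-2-yl to 4-(trifluoromethyl)benzyl stays unknown: the limit of > 58300 nM in this assay, at which 1 of the 4 values shown sits.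

The compounds shown leave open whether any gap from compound 3 comes from the pyridine nitrogen or from the methylene link of the benzyl groups, a question that a pyridin-2-ylmethyl group or an unsubstituted benzyl on the same ring nitrogen could help to separate. They also leave open how a carboxylic acid or an amine on the benzyl ring would read in this assay.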